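Acrylamide-bearing anilide set: estimate for a fluorophenyl analogue

This account rests on a few compounds, and the source may have more. Where it says the series, first, only, none or still open, it means among the compounds named here.

Measured compounds in a functional assay on MGC-803 cells (Homo sapiens) for inhibition, read by MTT assay, with a stated time of 72 h; on this read-out higher numbers stand for weaker inhibition and lower numbers for stronger inhibition:
compound 1 `O=C(CSc1nc(Nc2ccccc2)c2ccccc2n1)Nc1ccccc1Br` gives 18600 nM
compound 2 `O=C(CSc1nc(Nc2ccccc2)c2ccccc2n1)Nc1cccc([N+](=O)[O-])c1` gives 28100 nM
compound 3 `C=CC(=O)Nc1cccc(NC(=O)CSc2nc(Nc3ccccc3)c3ccccc3n2)c1` gives 7310 nM

Compound 3 stands lowest of the three numbers in this assay. Its nearest neighbour is compound 1, with a 2.5-fold lower number from compound 1 to compound 3 (0.41 log units; beyond the scatter), and its furthest is compound 2, with a 3.8-fold lower number from compound 2 to compound 3 (0.58 log units; beyond the scatter). The step from compound 1 to compound 2 is a 1.5-fold higher number from compound 1 to compound 2 (0.18 log units; within the scatter).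

Compound 4 `O=C(CSc1nc(Nc2ccccc2)c2ccccc2n1)Nc1ccc(F)cc1` has not yet been measured in this assay. It differs from compound 3 in one place: 4-fluorophenyl in place of 3-((vinylcarbonyl)amino)phenyl on an amide-type nitrogen.

Going by the values given here, no measured step covers exactly this exchange. Among the compounds with values here, the steps that bear on it are those in which the 3-((vinylcarbonyl)amino)phenyl group of compound 3 is replaced by another substituted phenyl on the same amide-type nitrogen, read in reverse: from compound 3 to compound 1 and to compound 2 the numbers rise modestly, both beyond the scatter. On that basis compound 4 is expected to fall back toward the numbers of compound 1 and compound 2, with a modest rise expected as a 2.7-fold higher number from compound 3 to compound 4 (0.44 log units; beyond the scatter).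

For compound 4 the estimate in this assay is 20000 nM, with a range from 8000 nM to 50000 nM.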

Compound 4, half-maximal inhibitory concentration: > 50000 nM
Compound 4: only a limit was reported; the forecaster's own chance of this, stated with the estimate: 10%; middle value at least 2.5-fold (0.39 log units) away from the limit.
By their numbers in this assay, from the lowest: compound 3; then compounds 1 and 2 (each within the scatter of the next). At a limit, above all of these: compound 4.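

In this assay compound 4 gives only a limit, not a number: the limit of > 50000 nM in this assay, at which 1 of the 4 values shown sits.

Replacing the 3-((vinylcarbonyl)amino)phenyl group with 4-fluorophenyl on the amide-type nitrogen gives an at least 6.8-fold higher number from compound 3 to compound 4 (0.83 log units; beyond the scatter), and replacing 2-bromophenyl gives an at least 2.6-fold higher number from compound 1 to compound 4 (0.42 log units; beyond the scatter), so the substituted phenyl at this position can take the number beyond the scatter of compound 1 as well as compound 3. Against the 3-nitrophenyl group the floor is an at least 1.7-fold higher number from compound 2 to compound 4 (0.25 log units; that floor lies within the scatter), so compound 4 is not yet separated from compound 2.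

As far as these compounds go, the true size of all three steps remains open, since each rests on a limit. Also open, from the compounds shown here alone, is whether the lower number of compound 3 needs the double bond of the (vinylcarbonyl)amino group, or whether a propanoylamino group or a plain amine on that aromatic carbon would give a similar number.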